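A Branched Chain Variant of Compound 1

The compounds below may be only part of what the source reports. "The series", "measured", "known", "first", "only" and "open" are said of these compounds alone.

In an in vitro functional assay on cells for agonist activity at Bombesin receptor subtype-3 (Mus musculus), read by luminescence and calcium flux (on this read-out lower numbers stand for an effect already at smaller amounts and higher numbers for an effect only at larger amounts of compound), compound 1 `CCCCc1cnc(C(CCC)Cc2ccc(-c3ccccc3C(=O)O)cc2)[nH]1` gives 165 nM, the highest of the two numbers at hand. Compound 2 `O=C(O)c1ccccc1-c1ccc(CCc2ncc(CC3CCC3)[nH]2)cc1` gives 7.1 nM, a gap that lies beyond the usual scatter of repeated measurements. Compound 3 `CCCCc1cnc(C(Cc2ccc(-c3ccccc3C(=O)O)cc2)C(C)C)[nH]1` differs from compound 1 by isopropyl in place of propyl on a saturated chain carbon bound to an aromatic carbon and a saturated chain carbon, the two sharing the same atoms joined differently. Within the data shown here, no pair of measured compounds traces this change, so nothing measured anchors it. For compound 3 the step of a 1.2-fold higher number from compound 1 to compound 3 (0.08 log units; within the scatter) is expected to remain within the usual scatter. Compound 3 is therefore estimated at 200 nM, with a range from 70 nM to 600 nM.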

Compound 3, half-maximal effective concentration: 2240 nM
Compound 3: middle estimate off by 11-fold (1.05 log units), on the low side, and the stated range ends below it.
By their numbers in this assay, from the lowest: compound 2; then compound 1; then compound 3.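

Isopropyl in place of propyl on a saturated chain carbon bound to an aromatic carbon and a saturated chain carbon gives a 14-fold higher number from compound 1 to compound 3 (1.13 log units; beyond the scatter), so this position responds strongly to how the same atoms are joined. The earlier compounds shown here could not show this, as no measured pair among them differed in one place. Nothing at hand accounts for the size of this step. From the compounds shown here alone, whether ethyl, cyclopropyl or a longer chain at this position would stay close to compound 1 remains open, as does whether the same exchange would carry a comparable penalty with cyclobutylmethyl in place of butyl elsewhere on the core.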